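Carbonyl substituent change from compound 2 to compound 4

A few compounds are considered here, and "the series" means these few. Any claim that something is new, unique, unknown or untested is made for them only; others in the source may bear on it.

Compound 2 `COc1cc(-c2nn(-c3cccc(NC(=O)c4cccc(C(F)(F)F)c4)c3)cc2-c2ccncc2)ccc1Cl` gives 2490 nM in a functional assay on SK-MEL-28 cells (Homo sapiens) for inhibition, read by sulforhodamine B assay, with a stated time of 48 h (on this read-out higher numbers stand for weaker inhibition of growth and lower numbers for stronger inhibition of growth), the second highest of the three measured numbers. Compound 1 `COc1cc(-c2nn(-c3cccc(NC(=O)c4ccc(Cl)c(C(F)(F)F)c4)c3)cc2-c2ccncc2)ccc1Cl` gives 3080 nM, and the step of a 1.2-fold lower number from compound 1 to compound 2 (0.09 log units; within the scatter) lies within the scatter. Compound 3 `O=C(Nc1cccc(-n2cc(-c3ccncc3)c(-c3ccc(Cl)c(O)c3)n2)c1)Nc1cc(C(F)(F)F)cc(C(F)(F)F)c1` gives 796 nM, a lower number beyond the scatter relative to compound 2. Compound 4 `COc1cc(-c2nn(-c3cccc(NC(=O)Nc4cccc(C(F)(F)F)c4)c3)cc2-c2ccncc2)ccc1Cl` differs from compound 2 in one place: (3-(trifluoromethyl)phenyl)amino in place of 3-(trifluoromethyl)phenyl on a carbonyl carbon. Among the measured compounds shown here, no measured step covers this change; the only measured step concerns a different place. Compound 3 also bears an amino group on its carbonyl carbon, but differs from compound 2 elsewhere as well, so its lower number guides only loosely. For compound 4 a lower number is expected, estimated at 1200 nM within 400 nM to 3500 nM. This expectation corresponds to a step of a 2.1-fold lower number from compound 2 to compound 4 (0.32 log units; beyond the scatter).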

Compound 4, concentration for 50% growth inhibition: 1120 nM
For compound 4 the middle estimate is 1.1-fold (0.03 log units) above the measured one, and the stated range covers the measured number.
By their numbers in this assay, from the lowest: compounds 3 and 4 (each within the scatter of the next); then compounds 2 and 1 (each within the scatter of the next).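

In this assay, among the compounds shown here, the carbonyl carbon is the first position where a single change moves the number beyond the scatter: (3-(trifluoromethyl)phenyl)amino in place of 3-(trifluoromethyl)phenyl gives a 2.2-fold lower number from compound 2 to compound 4 (0.35 log units; beyond the scatter). The same entering group in place of 4-chloro-3-(trifluoromethyl)phenyl gives a 2.8-fold lower number from compound 1 to compound 4 (0.44 log units; beyond the scatter). No measurement available here accounts for either step.

Still open, going by these compounds, is whether another link on this carbonyl carbon, such as an N-methylamino group or an ether oxygen, would give a similar number. Also open, on these data alone, is whether a chloro on the aromatic ring of the entering group would change it.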